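A Methyl Added to the Weakest Compound

The source may report more compounds than this note shows. Statements on the series, on what has been measured and on what is new or still open speak of the compounds shown alone.

Values in a functional assay on HL-60 cells (Homo sapiens), with a stated time of 4 days; a lower number here means a stronger inhibitor, a higher number a weaker inhibitor:
Compound 1 `CCCCCCNC(=O)c1[nH]cnc1C(=O)Nc1ccc(Cl)c(Cl)c1` gives 7800 nM
Compound 2 `O=C(Nc1ccc(Cl)c(Cl)c1)c1nc[nH]c1C(=O)NCc1ccc(Cl)cc1` gives 8800 nM
Compound 3 `CC(C)(C)OC(=O)CNC(=O)c1[nH]cnc1C(=O)Nc1ccc(Cl)c(Cl)c1` gives 25400 nM

Compound 3 has the highest number of the three, which makes it the weakest inhibitor here. Compound 4 `C[C@H](NC(=O)c1[nH]cnc1C(=O)Nc1ccc(Cl)c(Cl)c1)C(=O)OC(C)(C)C` differs from it by methyl in place of hydrogen on a saturated chain carbon bound to an amide-type nitrogen and a carbonyl carbon. Going by the values given here, no measured step tests this change directly. The closest guides are swaps of whole groups on the chain: a 3.3-fold higher number from compound 1 to compound 3 (0.51 log units; beyond the scatter) and a 2.9-fold higher number from compound 2 to compound 3 (0.46 log units; beyond the scatter) were modest, and a 1.1-fold higher number from compound 1 to compound 2 (0.05 log units; within the scatter) stayed within the scatter. One added methyl is therefore expected to give no shift beyond the scatter in this assay and the estimated step is a 1.0-fold lower number from compound 3 to compound 4 (0.01 log units; within the scatter) for now. Compound 4 is estimated at 25000 nM with 11000 nM to 55000 nM as its expected range.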

Compound 4, half-maximal inhibitory concentration: 2400 nM
Compound 4: the middle estimate sits 10-fold (1.02 log units) above what was measured; the whole stated range lies above it.
By their numbers in this assay, from the lowest: compound 4; then compounds 1 and 2 (each within the scatter of the next); then compound 3.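

In this assay, this saturated chain carbon proves far more sensitive than the earlier swaps of whole groups suggested: methyl in place of hydrogen alone gives the largest step seen so far (an 11-fold lower number from compound 3 to compound 4 (1.02 log units; beyond the scatter)). The new 1-(tert-butoxycarbonyl)ethyl group on the amide-type nitrogen also gives lower numbers than 4-chlorobenzyl (a 3.7-fold lower number from compound 2 to compound 4 (0.56 log units; beyond the scatter)) and hexyl (a 3.3-fold lower number from compound 1 to compound 4 (0.51 log units; beyond the scatter)). No measurement here accounts for the effect of this methyl. Still open, from the compounds shown here alone, is whether ethyl on this carbon would lower the number further. Going by these compounds, it is also open whether the gain survives with a carboxylic acid in place of the tert-butoxycarbonyl group.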